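Masking a Hydroxy Group: From Compound 3 to Compound 4

A few compounds are considered here, and "the series" means these few. Any claim that something is new, unique, unknown or untested is made for them only; others in the source may bear on it.

Compound 1 `CCCC/C=C\CCCCCCCCCc1cc(=O)c2c(O)cc(OCOC)cc2o1`: > 87000 nM (a limit, not a number)
Compound 2 `CCCCC/C=C\C/C=C\CCCCCCCc1cc(=O)c2c(O)c(C)c(OCOC)cc2o1`: > 87000 nM (a limit, not a number)
Compound 3 `CCCCC/C=C\C/C=C\CCCCCCCc1cc(=O)c2c(O)cc(O)cc2o1`: 6790 nM

For the measured compounds named here, in a functional assay on MDA-MB-231 cells (Homo sapiens) for antiproliferative activity, read by MTT assay (a higher number here means a weaker inhibitor, a lower number a stronger inhibitor), compound 3 holds the only true number, 6790 nM. The other two entries are limits. Compound 4 `CCCCC/C=C\C/C=C\CCCCCCCc1cc(=O)c2c(O)cc(OCOC)cc2o1` differs from compound 3 in one place: methoxymethyl in place of hydrogen on an oxygen on an aromatic ring. Going by the values given here, no measured pair isolates this change, so its size can only be judged indirectly. Compound 1 also carries a methoxymethoxy group and gives only a limit, > 87000 nM. Compound 2 carries one too and also gives only a limit, > 87000 nM. On that basis, a large weakening is expected in this assay, and the estimated change is an 8.8-fold higher number from compound 3 to compound 4 (0.95 log units; beyond the scatter). Compound 4 is estimated at 60000 nM, with an expected range of 20000 nM to 87000 nM.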

Compound 4, half-maximal inhibitory concentration: > 87000 nM
Compound 4 gave a limit, no number (the forecaster's own chance of this, stated with the estimate: 65%); at least 1.4-fold (0.16 log units) between middle value and limit.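

In this assay, going from hydroxy to methoxymethoxy gives an at least 12-fold higher number from compound 3 to compound 4 (1.10 log units; beyond the scatter), the first direct measure of this change, made with the chain held the same. Compound 4 gives > 87000 nM, which is a limit and not a number. The steps linking compound 4 to compound 1 and compound 2 cannot be read, because both ends of each step sit at a limit: the limit of > 87000 nM in this assay, at which 3 of the 4 values shown sit.

From the compounds shown here alone, the full size of the loss stays open. So does whether a methyl or an acetyl group on this oxygen would keep any of the activity of compound 3.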